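Working notes on a small agonist series, next compound pending

A few compounds are considered here, and "the series" means these few. Any claim that something is new, unique, unknown or untested is made for them only; others in the source may bear on it.

Measured so far in a functional assay on HEK293 cells for agonist activity at G-protein coupled receptor 39 (Homo sapiens), read by inositol phosphate accumulation; a higher number here means that more compound is needed for the effect, a lower number that less compound is needed:
compound 1, `CNc1nc(NCc2ccc(NC(C)=O)cc2)cc(-c2ccccn2)n1`: 5 nM
compound 2, `COCCNc1nc(NCC2CC2)cc(-c2ccccn2)n1`: 2200 nM

Compound 2 holds the highest of the two numbers in this assay; its nearest neighbour is compound 1, whose number is far lower, beyond the scatter. Compound 3, `CC(C)(C)CNc1nc(NCC2CC2)cc(-c2ccccn2)n1`, differs from compound 2 in one place: tert-butyl in place of methoxymethyl on a saturated chain carbon bound to a nitrogen on an aromatic ring. For the measured compounds named here, no measured pair shows this same change, so there is nothing to read a step from. The step from compound 2 to compound 3 is expected to be small, a 1.5-fold lower number from compound 2 to compound 3 (0.17 log units; within the scatter), near the scatter and with no firm direction. Compound 3 is estimated at 1500 nM, within 300 nM to 6000 nM.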

Compound 3, half-maximal effective concentration: 5000 nM
The estimate for compound 3 lay 3.3-fold (0.52 log units) below the measured number, and the stated range covers the measured number.
By their numbers in this assay, from the lowest: compound 1; then compound 2; then compound 3.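

Placing tert-butyl where compound 2 carries methoxymethyl, on a saturated chain carbon bound to a nitrogen on an aromatic ring, gives a 2.3-fold higher number from compound 2 to compound 3 (0.36 log units; beyond the scatter) as the first reading at this position. The step is modest but beyond the scatter, so this change is not neutral, and the number moves up when the oxygen leaves. No measurement here explains the step.

Going by these compounds, whether the oxygen or the chain shape governs the step remains open. So does how an amine or a carboxylic acid at this position would read.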